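A few compounds are considered here, and "the series" means these few. Any claim that something is new, unique, unknown or untested is made for them only; others in the source may bear on it.

Working notes on the series, read in a physicochemical assay for solubility, read by LC-MS, in phosphate buffer, with a stated time of 24 h, at pH 7.4; on this read-out lower numbers stand for lower solubility and higher numbers for higher solubility. Compound 1 `O=C(Nc1ccccc1)c1cnc(NCc2c(F)ccc3c2CCO3)n2cnnc12` gives < 1000 nM, which is a limit of the assay and not a number. Compound 2 `Cn1cc(-c2cnc(NCc3c(F)ccc4c3CCO4)c3cn[nH]c(=O)c23)cn1` gives 1000 nM, and compound 3 `Cn1nccc1-c1cnc(NCc2c(F)ccc3c2CCO3)c2cn[nH]c(=O)c12` gives 2000 nM.

Compound 4 `C[C@@H]1CC(=O)N(c2cnc(NCc3c(F)ccc4c3CCO4)n3cnnc23)C1` keeps the core of compound 1 and differs in one place: 4-methyl-2-oxopyrrolidin-1-yl in place of phenylcarbamoyl on an aromatic carbon. In words, 4-methyl-2-oxopyrrolidin-1-yl stands in place of phenylcarbamoyl on an aromatic carbon.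

For the measured compounds named here, no measured step covers this exchange. Going by the values given here, the only measured step is a 2.0-fold higher number from compound 2 to compound 3 (0.30 log units; within the scatter), which swaps a different pair of groups on a different core, so it bears on the change only loosely. It does show a change of group on an aromatic carbon staying small, and on that basis a large move is not expected in this assay. On thin evidence, the modest upward step expected here is estimated to be an at least 2.5-fold higher number from compound 1 to compound 4 (0.39 log units; beyond the scatter). For compound 4 the estimated value is 2500 nM, with an expected range of 700 nM to 10000 nM.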

Compound 4, solubility: 130000 nM
Compound 4: middle estimate off by 52-fold (1.72 log units), on the low side, outside the stated range (above it).
By their numbers in this assay, from the lowest: compounds 2 and 3 (each within the scatter of the next); then compound 4.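

In this assay, for the compounds shown here, 4-methyl-2-oxopyrrolidin-1-yl in place of phenylcarbamoyl gives an at least 130-fold higher number from compound 1 to compound 4 (2.11 log units; beyond the scatter), so a change of group at this aromatic carbon can produce a large step, whereas the only earlier step, a 2.0-fold higher number from compound 2 to compound 3 (0.30 log units; within the scatter), on a different core, showed no such move. For compound 1 the starting point is a limit and not a number: the limit of < 1000 nM in this assay, at which 1 of the 4 values shown sits. The step is therefore printed as a minimum, and its true size is not fixed.

The exchange removes the six-membered aromatic ring and the hydrogen-bond donor of phenylcarbamoyl and brings in a defined stereocentre, and this single step cannot separate these differences. On these data alone, how a simple amine, a carboxylic acid or the 2-oxopyrrolidin-1-yl ring without its methyl would read at this position remains open, as does whether the exchange would carry over to the core of compound 2.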